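The source may hold more compounds than are shown below. What is called first, only, known or untested is meant among the compounds shown, and "the series" means these compounds.

Of the compounds shown here, three with a shared core have been tested in a functional assay on MCF7 cells (Homo sapiens) for antiproliferative activity, read by sulforhodamine B assay, with a stated time of 48 h; on this read-out lower numbers stand for stronger inhibition and higher numbers for weaker inhibition. Compound 2 `CCCCCC(=O)Nc1ccc(S(=O)(=O)Oc2ccccc2C(C)C)cc1` gives 5300 nM. Compound 3 `CCCCCC(=O)Nc1ccc(S(=O)(=O)Oc2ccccc2I)cc1`, which carries iodo in place of isopropyl on an aromatic carbon, gives 10000 nM; the step of a 1.9-fold higher number from compound 2 to compound 3 (0.28 log units; within the scatter) lies within the scatter, so the two numbers cannot be told apart. Compound 1 `CCCCCC(=O)Nc1cccc(S(=O)(=O)Oc2ccccc2C(C)C)c1`, in which the amide sits at a different position of the ring, gives 12000 nM, a higher number than compound 2 by a margin beyond the scatter. Compound 2 therefore holds the lowest number that is clearly separated from another.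

Compound 4 `CC(C)c1ccccc1OS(=O)(=O)c1ccc(NC(=O)CCCl)cc1` is the next step from compound 2. The change is chloro in place of propyl on a saturated chain carbon, two bonds along the chain from a carbonyl carbon. For the measured compounds named here, the only step measured so far, from compound 2 to compound 3, concerns an aromatic substituent, not the amide chain, so it does not bear on this change directly; the comparison of compound 1 with compound 2 concerns the ring position of the amide and also says nothing about the chain. Going by the values given here, no measured step shows what a shorter, chlorine-bearing acyl chain does, so no direction beyond the scatter is expected here, and the estimated step of a 1.1-fold higher number from compound 2 to compound 4 (0.05 log units; within the scatter) reflects that. Compound 4 is expected to give about 6000 nM, in a range from 2500 nM to 15000 nM.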

Compound 4, half-maximal inhibitory concentration: 9000 nM
For compound 4 the middle estimate is 1.5-fold (0.18 log units) below the measured one; the range from low to high includes it.
By their numbers in this assay, from the lowest: compounds 2, 4, 3 and 1 (each within the scatter of the next, the first and the last beyond it).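

For the compounds shown here, the chain on the amide carbonyl is the new place touched here, since the earlier comparisons concerned the aromatic substituent and the ring position of the amide. In this assay, the step of a 1.7-fold higher number from compound 2 to compound 4 (0.23 log units; within the scatter) leaves the two compounds impossible to tell apart. Read one bond further out, the pentyl chain of compound 2 can give way to the 2-chloroethyl chain of compound 4, with three carbons leaving and one chlorine entering, and no difference beyond the scatter appears in this read-out. Nothing available explains this result, and the numbers alone cannot tie it to any feature of the chain.

This single change shortens the chain and adds chlorine together, so the two cannot be judged separately; a plain ethyl chain in the same place would be needed to pull them apart. As far as these compounds go, it also remains open whether a longer chain such as heptyl, or an amine or a carboxylic acid at the end of the chain, would shift the number beyond the scatter.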